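Replacing 1H-pyrrol-3-yl with pyridin-3-yl: an expected step

This account rests on a few compounds, and the source may have more. Where it says the series, first, only, none or still open, it means among the compounds named here.

Three compounds have been measured in a functional assay on MCF7 cells (Homo sapiens) for inhibition, read by MTT assay, with a stated time of 72 h, tested at 10 uM; on this read-out lower numbers stand for less inhibition and higher numbers for more inhibition at the one concentration tested (going by the name of the read-out):
Compound 1 `CCOC(=O)C1=C(Nc2ccccc2)S/C(=C\c2ccc(O)c(O)c2)C1=O` gives 38.1%.
Compound 2 `CCOC(=O)C1=C(Nc2ccccc2)S/C(=C\c2ccc(OC)cc2)C1=O` gives 14.7%.
Compound 3 `CCOC(=O)C1=C(Nc2ccccc2)S/C(=C\c2cc[nH]c2)C1=O` gives only a limit, < 10%.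

Compound 3 thus stands at the floor of the measured range (the limit of < 10% in this assay, at which 1 of the 3 values shown sits), reached by the step of a number at least 28.1 percentage points lower from compound 1 to compound 3 (beyond the scatter) and the step of a number at least 4.7 percentage points lower from compound 2 to compound 3 (that floor lies within the scatter), the latter within the scatter. Compound 4 `CCOC(=O)C1=C(Nc2ccccc2)S/C(=C\c2cccnc2)C1=O` differs from compound 3 by pyridin-3-yl in place of 1H-pyrrol-3-yl on a double-bonded chain carbon bound to a double-bonded ring carbon. Among the measured compounds shown here, no measured step swaps one small heteroaromatic ring for another, so no step bears directly on this change; the steps of a number 23.4 percentage points lower from compound 1 to compound 2 (beyond the scatter) and a number at least 28.1 percentage points lower from compound 1 to compound 3 (beyond the scatter) only show that moving away from 3,4-dihydroxyphenyl lowers inhibition. Compound 4 is therefore expected to stay close to compound 3, with a step of a number no lower from compound 3 to compound 4 (the limit leaves the size open) of no size beyond the scatter, estimated at 10%, ranging from 0% to 25%.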

Compound 4, a percentage reported as inhibition, at one concentration (the size of the read-out at that concentration, not a potency): < 10%
Compound 4 gave a limit, no number (the forecaster's own chance of this, stated with the estimate: 55%); the middle value lies on the limit itself.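

In this assay compound 4 gives only a limit, not a number, so a second compound now sits at the floor of the read-out: the limit of < 10% in this assay, at which 2 of the 4 values shown sit.

Moving to pyridin-3-yl from 3,4-dihydroxyphenyl gives a clear loss, a number at least 28.1 percentage points lower from compound 1 to compound 4 (beyond the scatter), whereas moving from 4-methoxyphenyl gives only a number at least 4.7 percentage points lower from compound 2 to compound 4 (that floor lies within the scatter). The step between the two limits cannot be read, so swapping 1H-pyrrol-3-yl for pyridin-3-yl has no measurable size here.

On these data alone, it remains open whether an amine or a carboxylic acid in place of the hydroxyl groups of compound 1 would keep its inhibition. As far as these compounds go, how compound 3 and compound 4 rank under the limit also stays unknown.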